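This account rests on a few compounds, and the source may have more. Where it says the series, first, only, none or still open, it means among the compounds named here.

Compound 3 `CCCCCc1nn(C[C@H]2CCCN2C)c(=O)c2ccccc12` gives 1000 nM in an assay for binding affinity to Alpha-1B adrenergic receptor (Homo sapiens) (on this read-out higher numbers stand for weaker inhibition and lower numbers for stronger inhibition), the higher of the two numbers in the set; the nearest number is that of compound 1 `CN1CCC[C@@H]1Cn1nc(Cc2ccc(F)c(F)c2)c2ccccc2c1=O`, which gives 316 nM. Compound 2 `COC(=O)c1ccc(Cc2nn(C[C@H]3CCCN3C)c(=O)c3ccccc23)cc1` reaches only a limit of the assay, > 1990 nM in this assay. Compound 4 `COc1ccc(Cc2nn(C[C@H]3CCCN3C)c(=O)c3ccccc23)cc1` is not yet measured; it differs from compound 3 by 4-methoxyphenyl in place of butyl on a saturated chain carbon bound to an aromatic carbon. Among the measured compounds shown here, the one measured step that bears on this change, the replacement of 3,4-difluorophenyl by butyl in a 3.2-fold higher number from compound 1 to compound 3 (0.50 log units; beyond the scatter), ran the opposite way and is the basis for expecting compound 4 to move back toward compound 1, though compound 2 sits at the limit of > 1990 nM in this assay, at which 1 of the 3 values shown sits, so an aromatic ring alone does not fix the number. The expected step is a 2.0-fold lower number from compound 3 to compound 4 (0.30 log units; within the scatter), a modest fall. Compound 4 is estimated at 500 nM, within 150 nM to 2000 nM.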

Compound 4, inhibition constant: 158 nM
For compound 4 the middle estimate is 3.2-fold (0.50 log units) above the measured one, and the stated range covers the measured number.
By their numbers in this assay, from the lowest: compounds 4 and 1 (each within the scatter of the next); then compound 3. At a limit, above all of these: compound 2.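

On a saturated chain carbon bound to an aromatic carbon, 4-methoxyphenyl in place of butyl gives a 6.3-fold lower number from compound 3 to compound 4 (0.80 log units; beyond the scatter) in this assay, while 4-methoxyphenyl in place of 3,4-difluorophenyl gives a 2.0-fold lower number from compound 1 to compound 4 (0.30 log units; within the scatter), so these two rings are not separated. What the ring carries matters: on an aromatic carbon, methoxy in place of methoxycarbonyl gives an at least 12-fold lower number from compound 2 to compound 4 (1.10 log units; beyond the scatter). The value of compound 2 is a limit, not a number: the limit of > 1990 nM in this assay, at which 1 of the 4 values shown sits.

Open, going by these compounds, is where a carboxylic acid or an amine on this ring would fall relative to methoxy and methoxycarbonyl. Also open, on these data alone, is whether a longer chain in place of butyl would shift the number.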